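Swapping Pyrrolidine for Morpholine on a Shared Core

This account rests on a few compounds, and the source may have more. Where it says the series, first, only, none or still open, it means among the compounds named here.

Compound 1 `CCOc1cc(NC(=O)C2(NC(=O)c3ccc4c(C5CCCC5)c(-c5ncc(Cl)cn5)n(C)c4c3)CCC2)ccc1/C=C/C(=O)OCC(N)=O` and compound 2 `CCOc1cc(NC(=O)C2(NC(=O)c3ccc4c(C5CCCC5)c(-c5ncc(Cl)cn5)n(C)c4c3)CCC2)ccc1/C=C/C(=O)OCC(=O)N1CCCC1` share one core and differ only at the tail of the chain. In an ADME assay (liver) for pharmacokinetics, with Liver microsome (Homo sapiens) as the target, using microsomes (on this read-out higher numbers stand for a longer-lived compound and lower numbers for a shorter-lived compound), compound 1 gives 0.983 h, and compound 2 gives 1.65 h. For the measured compounds named here, compound 2 thus stands at the top of these two numbers, yet the single step, a 1.7-fold higher number from compound 1 to compound 2 (0.22 log units; within the scatter), is within the scatter, so the two compounds cannot be separated with confidence on this read-out. Compound 3 `CCOc1cc(NC(=O)C2(NC(=O)c3ccc4c(C5CCCC5)c(-c5ncc(Cl)cn5)n(C)c4c3)CCC2)ccc1/C=C/C(=O)OCC(=O)N1CCOCC1` has not been measured; it differs from compound 2 in one place: morpholin-4-yl in place of pyrrolidin-1-yl on a carbonyl carbon. Going by the values given here, no measured step covers this exact change. Among the compounds with values here, the only step available, an amino group replaced by pyrrolidin-1-yl on a carbonyl carbon, stayed within the scatter, and the new change is of a similar kind, one saturated ring exchanged for another on the carbonyl carbon. The expected step is therefore a 1.1-fold lower number from compound 2 to compound 3 (0.04 log units; within the scatter), nothing beyond the scatter. Compound 3 is estimated at 1.5 h in this assay, with a range from 0.7 h to 3.2 h.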

Compound 3, half-life: 0.667 h
For compound 3 the middle estimate is 2.2-fold (0.35 log units) above the measured one, outside the stated range (below it).
By their numbers in this assay, from the lowest: compounds 3, 1 and 2 (each within the scatter of the next, the first and the last beyond it).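

At this position, on a carbonyl carbon whose other neighbour is a saturated chain carbon, two saturated rings prove not to be interchangeable in this assay (a 2.5-fold lower number from compound 2 to compound 3 (0.39 log units; beyond the scatter)), a modest step and the only one in this set that goes beyond the scatter. The amino group of compound 1 still cannot be told apart from morpholin-4-yl (a 1.5-fold lower number from compound 1 to compound 3 (0.17 log units; within the scatter)), so the clear difference here is between the two rings, with the amino compound within the scatter of each. The change swaps a five-membered ring for a six-membered ring and adds a ring oxygen that counts as a hydrogen-bond acceptor, but no measurement at hand explains why the number moves.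

These compounds leave ring size and the ring oxygen tied together, and piperidin-1-yl, a six-membered ring with nitrogen as its only hetero atom, would pull the two apart. Also open, as far as these compounds go, is whether the step would hold with a longer chain between the carbonyl carbon and the ester oxygen, or with a carboxylic acid at the end of the chain in place of the ring.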